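The compounds below may be only part of what the source reports. "The series", "measured", "known", "first", "only" and "open" are said of these compounds alone.

Working notes on the series.

Compound 1, `CC1C(=O)c2nc(CCCCN3N=C(Cl)CCC3=O)[nH]c2N(C)C1=O`, gives 370 nM in an assay on isolated protein for binding affinity to adenosine receptor A1 (Homo sapiens); on this read-out lower numbers stand for stronger inhibition and higher numbers for weaker inhibition. Compound 2, `CC1C(=O)c2nc(CCCCN3N=C(c4ccccc4)CCC3=O)[nH]c2N(C)C1=O`, is the same core with phenyl in place of chloro on a carbon with a double bond to nitrogen; in this assay compound 2 gives 2120 nM. That single change produced a 5.7-fold higher number from compound 1 to compound 2 (0.76 log units; beyond the scatter).

Compound 3, `CCCC1C(=O)c2nc(CCCN3N=C(Cl)CCC3=O)[nH]c2N(C)C1=O`, rests on a different core; the difference between the core of compound 1 and the core of compound 3 is not broken down here. In this assay compound 3 gives 1200 nM. Set against the others, compound 3 stands close to compound 2, the two values lying within the usual scatter of each other, while compound 1 sits clearly lower than compound 3.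

Compound 4, `CCCC1C(=O)c2nc(CCCN3N=C(c4ccccc4)CCC3=O)[nH]c2N(C)C1=O`, is not yet measured. It carries phenyl in place of chloro on a carbon with a double bond to nitrogen, the same change on the core of compound 3 that turns compound 1 into compound 2: the words describing the place are the same in both pairs, so the change is taken as the same one, not merely the same kind. Within the data shown here, the only guide to its size is the single earlier occurrence, and whether the step transfers unchanged onto the core of compound 3 cannot be checked from these data.

The expectation for compound 4 is a step of a 5.0-fold higher number from compound 3 to compound 4 (0.70 log units; beyond the scatter), taken over from compound 1 to compound 2 because the earlier step was a 5.7-fold higher number from compound 1 to compound 2 (0.76 log units; beyond the scatter). On that basis compound 4 is estimated at 6000 nM, with a plausible range from 2000 nM to 18000 nM, the width reflecting that one prior example and a change of core support the estimate.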

Compound 4, inhibition constant: 810 nM
Beside the measured number, compound 4's estimate is 7.4-fold (0.87 log units) above it; the measured number lies below the stated range.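

Phenyl in place of chloro does not act as a fixed increment in this assay: on the core of compound 3 it gives a 1.5-fold lower number from compound 3 to compound 4 (0.17 log units; within the scatter), and the two occurrences of the same change disagree: the same change on two cores in this assay, a 5.7-fold higher number (0.76 log units; beyond the scatter) from compound 1 to compound 2 and a 1.5-fold lower number (0.17 log units; within the scatter) from compound 3 to compound 4, 8.5-fold (0.93 log units) apart, beyond the scatter of two such steps. The clear loss seen on the core of compound 1 therefore cannot be carried over to the core of compound 3, and in this series the size of this change has to be read core by core. What remains unshown is which feature separating the two cores goes with the difference, and two pairs give no general rule and no explanation of it.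

Open, as far as these compounds go, is how other groups on the carbon with a double bond to nitrogen, such as methyl, methoxy, an amine or a pyridyl ring, would behave on each of the two cores, and whether they would follow the pattern of compound 1 and compound 2 or that of compound 3 and compound 4. Also open, from the compounds shown here alone, is how the same change would behave on a core that differs from the core of compound 1 in one feature only, for example a longer chain alone, which would begin to separate the contributions of the core.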